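Cyclohexylmethyl in place of cyclopropyl on the ring nitrogen

The source may report more compounds than this note shows. Statements on the series, on what has been measured and on what is new or still open speak of the compounds shown alone.

Compound 1 `Cc1cc(NC(=O)Cn2nnc(-c3ccccc3)n2)n(C2CCCCC2)n1` gives 92% in an assay on HEK293 cells for activation of Kir3.1/Kir3.2 (Homo sapiens), read by thallium flux; a lower number here means a smaller maximal response, a higher number a larger maximal response.
Compound 2 `Cc1cc(NC(=S)Cn2nnc(-c3ccccc3)n2)n(C2CCCCC2)n1` gives 80%.
Compound 3 `Cc1cc(NC(=O)Cn2nnc(-c3ccccc3)n2)n(C2CC2)n1` gives > 78%, a limit of the assay and not a number.

Compound 3 thus stands only at that limit, (the limit of > 78% in this assay, at which 1 of the 3 values shown sits), with no fixed place among the others. Compound 4 `Cc1cc(NC(=O)Cn2nnc(-c3ccccc3)n2)n(CC2CCCCC2)n1` differs from compound 3 in one spot: cyclohexylmethyl in place of cyclopropyl on an aromatic nitrogen. Among the measured compounds shown here, the only measured step at this position, a step that the limit leaves unreadable from compound 1 to compound 3, has one end at the limit and so gives no readable size, and no other measured step touches this group. Compound 1, which carries cyclohexyl, gives 92%. Compound 4 is therefore expected near 88%, in a range from 70% to 102%, and the expected step that the limit leaves unreadable from compound 3 to compound 4 cannot be sized against a limit.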

Compound 4, largest response reached (Emax), in percent of the reference or control that the assay uses: 77%
Beside the measured number, compound 4's estimate is 11 percentage points above it; the measured number falls inside the stated range.
By their numbers in this assay, from the lowest: compounds 4 and 2 (each within the scatter of the next); then compound 1.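

In this assay, cyclohexylmethyl in place of cyclohexyl on the aromatic nitrogen gives a number 15 percentage points lower from compound 1 to compound 4 (beyond the scatter), the first readable size for a change at this position. Cyclohexylmethyl in place of cyclopropyl gives a number at least 1 percentage points lower from compound 3 to compound 4 (that floor lies within the scatter), so that step has a floor but no real size. Compound 3 remains a limit and not a number: the limit of > 78% in this assay, at which 1 of the 4 values shown sits.

As far as these compounds go, how this position would respond to a phenyl ring, or to a longer chain ending in an amine, stays open. From the compounds shown here alone, whether cyclopropyl truly differs from cyclohexyl here also stays open.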